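Shortening the Sulfonamide Alkyl Chain in a Polyamine Series

The source may hold more compounds than are shown below. What is called first, only, known or untested is meant among the compounds shown, and "the series" means these compounds.

The measured compounds and their values in a functional assay on HEK293 cells (Homo sapiens) for inhibition; a higher number here means a weaker inhibitor, a lower number a stronger inhibitor:
Compound 1, `CCCCCCCCS(=O)(=O)NCCCNCCCNCCCCNCCCN`, gives 816 nM.
Compound 2, `CCCCCCCCCCCCS(=O)(=O)NCCCNCCCNCCCCNCCCN`, gives 190 nM.
Compound 3, `CCCCCCCCCCCCS(=O)(=O)NCCCNC/C=C/CNCCCN`, gives 522 nM.

Compound 4, `CCCCCCCCS(=O)(=O)NCCCNC/C=C/CNCCCN`, has not yet been measured in this assay. It differs from compound 3 in a single place: hydrogen in place of butyl on a saturated chain carbon, eight bonds along the chain from a sulfonyl sulfur. The same change, at the same place, is already known between two measured compounds: a 4.3-fold higher number from compound 2 to compound 1 (0.63 log units; beyond the scatter). Compound 3 carries a different core from compound 2; the difference between the two cores is not broken down here. In this assay compound 3 and compound 1 give numbers within the usual scatter of each other, while compound 2 gives a lower number than compound 3, beyond the scatter.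

Because a 4.3-fold higher number from compound 2 to compound 1 (0.63 log units; beyond the scatter) moved the number by a modest amount, the step from compound 3 to compound 4 is expected to be of similar size, a 4.2-fold higher number from compound 3 to compound 4 (0.62 log units; beyond the scatter). In this assay compound 4 is therefore estimated at about 2200 nM, with the expected range running from 900 nM to 5500 nM.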

Compound 4, half-maximal inhibitory concentration: 12700 nM
Beside the measured number, compound 4's estimate is 5.8-fold (0.76 log units) below it; the whole stated range lies below it.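

Swapping butyl for hydrogen, on a saturated chain carbon eight bonds along the chain from a sulfonyl sulfur, gives a 24-fold higher number from compound 3 to compound 4 (1.39 log units; beyond the scatter) in this assay, a much larger step than the same change produced on the core of compound 2. The change raises the number on both cores, so compounds 1 and 4 are both weaker inhibitors than their partners, but the size of the step does not carry over from one core to the other: the same change on two cores in this assay, a 4.3-fold higher number (0.63 log units; beyond the scatter) from compound 2 to compound 1 and a 24-fold higher number (1.39 log units; beyond the scatter) from compound 3 to compound 4, 5.7-fold (0.75 log units) apart, beyond the scatter of two such steps. This shows that the direction held in these two pairs; it does not show why the two cores respond differently, and two pairs give no rule for how the change would behave on a further core.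

The compounds shown leave open how the number moves with a decyl chain on either core, which would show whether the loss comes gradually or in one sharp drop. They also leave open whether a longer chain, such as a tetradecyl chain, would keep the two cores apart.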